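Swapping the aryl group on the shared core of compound 3

A few compounds are considered here, and "the series" means these few. Any claim that something is new, unique, unknown or untested is made for them only; others in the source may bear on it.

This series shares one core and varies the aryl group on a nitrogen on an aromatic ring. Compound 1 `Cc1cc(Nc2cc(N3CCN(C)CC3)nc(Nc3cccc(Cl)c3)n2)n[nH]1` gives 736 nM in a functional assay on HCT-116 cells (Homo sapiens) for antiproliferative activity, read by CCK-8 assay, with a stated time of 72 h (a lower number here means a stronger inhibitor, a higher number a weaker inhibitor), compound 2 `Cc1cc(Nc2cc(N3CCN(C)CC3)nc(Nc3ccc(Cl)cc3)n2)n[nH]1` gives 1370 nM, and compound 3 `Cc1cc(Nc2cc(N3CCN(C)CC3)nc(Nc3ccc(C#N)cc3)n2)n[nH]1` gives 650 nM. Compound 3 has the lowest number of the three: the step of a 1.1-fold lower number from compound 1 to compound 3 (0.05 log units; within the scatter) is within the scatter, while a 2.1-fold lower number from compound 2 to compound 3 (0.32 log units; beyond the scatter) is modest. Compound 4 `COc1cccc(Nc2nc(Nc3cc(C)[nH]n3)cc(N3CCN(C)CC3)n2)c1` carries 3-methoxyphenyl in place of 4-cyanophenyl on a nitrogen on an aromatic ring. Among the measured compounds shown here, the only step that bears on it is a 1.1-fold lower number from compound 1 to compound 3 (0.05 log units; within the scatter), which was within the scatter, so no change beyond the scatter is expected, perhaps a slightly higher number. For compound 4 the estimate is 850 nM, in the range 350 nM to 2000 nM, a step of a 1.3-fold higher number from compound 3 to compound 4 (0.12 log units; within the scatter).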

Compound 4, half-maximal inhibitory concentration: 923 nM
Compound 4: middle estimate off by 1.1-fold (0.04 log units), on the low side; measured number inside the range.
By their numbers in this assay, from the lowest: compounds 3, 1, 4 and 2 (each within the scatter of the next, the first and the last beyond it).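

In this assay, the 3-methoxyphenyl group on this nitrogen gives three steps, and a 1.4-fold higher number from compound 3 to compound 4 (0.15 log units; within the scatter) and a 1.5-fold lower number from compound 2 to compound 4 (0.17 log units; within the scatter) and a 1.3-fold higher number from compound 1 to compound 4 (0.10 log units; within the scatter) all lie within the scatter. Compound 4 thus cannot be told apart from any of the other three compounds, even though compound 2 and compound 3 differ from each other beyond the scatter, and methoxy in place of chloro brings no readable change. Nothing measured here explains these numbers. Going by these compounds, whether an amine or a carboxylic acid on this aryl ring would move the number beyond the scatter remains open, as does the effect of a longer alkoxy chain in place of methoxy.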